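Aryl Swap on a Shared Core: Expected Potency of Compound 4

A few compounds are considered here, and "the series" means these few. Any claim that something is new, unique, unknown or untested is made for them only; others in the source may bear on it.

Measured compounds in an assay for inhibition of 15-hydroxyprostaglandin dehydrogenase [NAD(+)] (Homo sapiens), read by fluorescence, with a stated time of 15 min, in the presence of a further agent that is not named here; on this read-out lower numbers stand for stronger inhibition and higher numbers for weaker inhibition:
compound 1, `CCCC[S+]([O-])c1nc2ccc(-c3cccs3)nc2s1`, gives 1230 nM
compound 2, `CCCC[S+]([O-])c1sc2nc(-c3nccs3)cc(-c3cccc(CO)c3)c2c1N`, gives 4.3 nM
compound 3, `CCCC[S+]([O-])c1sc2nc(-c3nccs3)cc(-c3ccc(COC(=O)CN(C)C)cc3)c2c1N`, gives 3.5 nM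

Compound 2 stands second highest of the three numbers in this assay. Its nearest neighbour is compound 3, whose value lies within the scatter of repeated measurements, so no order between compound 2 and compound 3 can be stated. Its furthest neighbour is compound 1, whose much higher number lies beyond the scatter; compound 1 also lacks the amine-bearing fused core that compound 2 and compound 3 share.

Compound 4, `CCCC[S+]([O-])c1sc2nc(-c3nccs3)cc(-c3cnc(C)[nH]3)c2c1N`, differs from compound 2 in one place: 2-methyl-1H-imidazol-5-yl in place of 3-(hydroxymethyl)phenyl on an aromatic carbon. Going by the values given here, no pair of measured compounds shows a step of this kind, so the size of the change is judged from the structures alone. In this assay the step of a 2.1-fold higher number from compound 2 to compound 4 (0.32 log units; beyond the scatter) is expected to be small and towards weaker inhibition, most likely not beyond the scatter. Compound 4 is therefore estimated at 9 nM, with a range from 3 nM to 40 nM.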

Compound 4, half-maximal inhibitory concentration: 2.3 nM
Beside the measured number, compound 4's estimate is 3.9-fold (0.59 log units) above it; measured number below the stated range.
By their numbers in this assay, from the lowest: compounds 4, 3 and 2 (each within the scatter of the next); then compound 1.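

In this assay the exchange of 3-(hydroxymethyl)phenyl for 2-methyl-1H-imidazol-5-yl is a 1.9-fold lower number from compound 2 to compound 4 (0.27 log units; within the scatter), so this single pair shows no difference that can be told from the scatter. Compound 2 and compound 3 carry a six-membered aromatic ring of carbon only at this position, whereas compound 4 shows that a five-membered aromatic ring with 2 hetero atoms can stand there on the shared core with no loss of inhibition beyond the scatter. Nothing measured here accounts for this result.

The compounds shown leave open whether the methyl group on the imidazole matters, since a plain imidazolyl or a longer alkyl chain in its place does not appear among them. They also leave open how a pyridyl ring, or a ring carrying an amine or a carboxylic acid, would read at this position.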